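Methylsulfanyl for methyl on two different cores

The compounds below may be only part of what the source reports. "The series", "measured", "known", "first", "only" and "open" are said of these compounds alone.

Compound 1 `Cc1ccc(Nc2ncnc3sc(Nc4c(Cl)cccc4Cl)nc23)cc1` gives 32 nM in a functional assay on HEK293 cells for antagonist activity at transient receptor potential cation channel subfamily V member 1 (Rattus norvegicus), read by calcium flux; on this read-out higher numbers stand for weaker inhibition and lower numbers for stronger inhibition. Compound 2 `CSc1ccc(Nc2ncnc3sc(Nc4c(Cl)cccc4Cl)nc23)cc1` gives 12 nM in this assay, and the change methylsulfanyl in place of methyl on an aromatic carbon produced a 2.7-fold lower number from compound 1 to compound 2 (0.43 log units; beyond the scatter). Compound 3 `Cc1nc(Nc2ccc(C(F)(F)F)c(Cl)c2)c2nc(Nc3c(Cl)cccc3Cl)sc2n1` gives 2 nM in this assay; the difference between its core and the core of compound 1 is not broken down here. Compound 4 `CSc1nc(Nc2ccc(C(F)(F)F)c(Cl)c2)c2nc(Nc3c(Cl)cccc3Cl)sc2n1` carries the same kind of change, (methylsulfanyl in place of methyl on an aromatic carbon), but the surroundings differ: in compound 1 the group sits on a six-membered aromatic ring of carbon only, para to a large group, whereas in compound 3 it sits on a ring with 2 nitrogen, between two ring nitrogen atoms, in a fused system. A step of a 1.7-fold lower number from compound 3 to compound 4 (0.22 log units; within the scatter) is expected, resting on a 2.7-fold lower number from compound 1 to compound 2 (0.43 log units; beyond the scatter) while allowing for the changed place. Compound 4 is estimated at 1.2 nM, between 0.4 nM and 4 nM.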

Compound 4, half-maximal inhibitory concentration: 113 nM
Estimate against measurement, compound 4: 94-fold (1.97 log units) below, outside the stated range (above it).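

In this assay methylsulfanyl in place of methyl gave a 57-fold higher number from compound 3 to compound 4 (1.75 log units; beyond the scatter) and so did not carry over from the other core, either in direction or in size: the same change on two cores in this assay, a 2.7-fold lower number (0.43 log units; beyond the scatter) from compound 1 to compound 2 and a 57-fold higher number (1.75 log units; beyond the scatter) from compound 3 to compound 4, 150-fold (2.18 log units) apart, beyond the scatter of two such steps. A step read on one of these cores is therefore a poor guide to the same change on the other. Within the data shown here, with only two pairs, this does not show which difference between the cores sets the steps apart, since the group sits in a different place and the rest of the molecule differs too.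

Open, from the compounds shown here alone, is how the place between two ring nitrogen atoms responds to other groups, such as an amine or an ethyl chain. Also open, going by these compounds, is whether the step would be the same with the aromatic group of compound 1 on the core of compound 3.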